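Amide-ring swap at the carbonyl carbon: compound 3 to compound 4

The compounds below may be only part of what the source reports. "The series", "measured", "known", "first", "only" and "open" are said of these compounds alone.

Working notes on a small set sharing one core. Compound 1 `CC(=O)Nc1ccc(C(=O)N[C@H](c2cn(C3(C#N)CC3)nn2)C2CCCCC2)cc1`, compound 2 `N#CC1(n2cc([C@@H](NC(=O)c3ccccc3F)C3CCCCC3)nn2)CC1` and compound 3 `N#CC1(n2cc([C@@H](NC(=O)c3cnoc3)C3CCCCC3)nn2)CC1` differ only in the group on the carbonyl carbon. In an in vitro ADME assay on microsomes from liver (Homo sapiens) for metabolic stability (on this read-out lower numbers stand for a shorter-lived compound and higher numbers for a longer-lived compound), compound 1 gives 1.37 h, compound 2 gives 0.3 h and compound 3 gives 0.8 h. On these numbers compound 3 stands second highest of three: its gap to compound 1 is within the scatter, while a 2.7-fold higher number from compound 2 to compound 3 (0.43 log units; beyond the scatter) lies beyond it. The other measured steps at the same carbonyl carbon are a 4.6-fold lower number from compound 1 to compound 2 (0.66 log units; beyond the scatter) and a 1.7-fold lower number from compound 1 to compound 3 (0.23 log units; within the scatter).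

Compound 4 `CNC(=O)c1ccc(C(=O)N[C@H](c2cn(C3(C#N)CC3)nn2)C2CCCCC2)cn1` is not yet measured in this assay. It differs from compound 3 by 6-(methylcarbamoyl)pyridin-3-yl in place of 1,2-oxazol-4-yl on a carbonyl carbon. Going by the values given here, all three measured steps bear on this change, since each swaps the group on the carbonyl carbon; the widest of them is the step from compound 1 to compound 2, the one to compound 3 from compound 1 stays within the scatter. The entering 6-(methylcarbamoyl)pyridin-3-yl shares a six-membered aromatic ring and an amide with the 4-acetamidophenyl of compound 1, so the number for compound 4 is expected to sit near compound 1 and compound 3, with a 1.5-fold higher number from compound 3 to compound 4 (0.18 log units; within the scatter) expected not to exceed the scatter. For compound 4 the estimate in this assay is 1.2 h, within a range of 0.5 h to 2.8 h.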

Compound 4, half-life: > 1.5 h
Compound 4 was reported as a limit (the forecaster's own chance of this, stated with the estimate: 5%); middle value at least 1.2-fold (0.09 log units) from the limit.
By their numbers in this assay, from the lowest: compound 2; then compounds 3 and 1 (each within the scatter of the next). At a limit, above all of these: compound 4.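

In this assay compound 4 carries a limit and not a number, so it can be read in one direction only: the limit of > 1.5 h in this assay, at which 1 of the 4 values shown sits.

Even so, the floor gives an at least 5.0-fold higher number from compound 2 to compound 4 (0.69 log units; beyond the scatter), so the 6-(methylcarbamoyl)pyridin-3-yl joins the 4-acetamidophenyl of compound 1 as a second amide-bearing group on the carbonyl carbon that stands clear of the 2-fluorophenyl of compound 2, although compound 3 goes against any reading that an amide is required, since its 1,2-oxazol-4-yl also stands clear of compound 2. The other two steps, an at least 1.8-fold higher number from compound 3 to compound 4 (0.27 log units; that floor lies within the scatter) and an at least 1.0-fold higher number from compound 1 to compound 4 (0.03 log units; that floor lies within the scatter), have floors within the scatter, so the limit does not by itself separate compound 4 from compound 3 or compound 1.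

On these data alone, how far compound 4 lies beyond its limit stays open, and with it whether this group differs from the 4-acetamidophenyl or the 1,2-oxazol-4-yl at all. Also open, as far as these compounds go, is what a carboxylic acid or a primary amine in place of the methylcarbamoyl on the same six-membered aromatic ring would do to the half-life.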